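The source may hold more compounds than are shown below. What is called first, only, known or untested is meant among the compounds shown, and "the series" means these compounds.

Of the compounds shown here, two sharing one core have been tested in a functional assay on HT-29 cells (Homo sapiens) for antiproliferative activity, read by sulforhodamine B assay, with a stated time of 48 h; on this read-out lower numbers stand for stronger inhibition and higher numbers for weaker inhibition. Compound 1 `O=C1NCCN1c1ccc(S(=O)(=O)Nc2ccc(C3CCCCC3)cc2)cc1` gives > 1000 nM, which is a limit of the assay and not a number. Going by the values given here, compound 2 `CCCCOc1ccc(NS(=O)(=O)c2ccc(N3CCNC3=O)cc2)cc1` gives 630 nM, the only actual number so far. Compound 3 `CCCCCc1ccc(NS(=O)(=O)c2ccc(N3CCNC3=O)cc2)cc1` has not yet been measured. It carries pentyl in place of butoxy on an aromatic carbon, para to a large group: pentyl in place of butoxy on an aromatic carbon. Among the compounds with values here, only one measured step bears on this change, and it bears loosely. Going by these compounds, it is an at least 1.5-fold lower number from compound 1 to compound 2 (0.20 log units; that floor lies within the scatter), with butoxy in place of cyclohexyl on an aromatic carbon, and its true size stays open, for it rests on (the limit of > 1000 nM in this assay, at which 1 of the 2 values shown sits). In that step a ring group leaves, whereas neither group in the new change has a ring. On the strength of that step alone, no change beyond the scatter is expected in this assay, and the data favour no clear direction. The expected change is a 1.3-fold higher number from compound 2 to compound 3 (0.10 log units; within the scatter), which is a small one. For compound 3 the estimated value is 800 nM, within an expected range of 300 nM to 2500 nM.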

Compound 3, half-maximal inhibitory concentration: 990 nM
For compound 3 the middle estimate is 1.2-fold (0.09 log units) below the measured one, within the range that was stated.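

In this assay, going by these compounds alone, pentyl in place of butoxy gives the first step at this position with a real number at both ends, namely a 1.6-fold higher number from compound 2 to compound 3 (0.20 log units; within the scatter). On an aromatic carbon para to a large group, then, the butoxy oxygen, which is the one hydrogen-bond acceptor that leaves, can give way to carbon with no change beyond the scatter, at least between these two ringless chains of equal heavy-atom count. Compound 1 stands at a limit of the assay and not at a number. Pentyl in place of cyclohexyl gives only a number no higher from compound 1 to compound 3 (the limit leaves the size open), a step that cannot be read, which leaves the cyclohexyl ring unplaced against either chain because of this: the limit of > 1000 nM in this assay, at which 1 of the 3 values shown sits.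

The compounds shown leave open whether a longer chain such as heptyl, or a shorter one such as ethoxy, would move the number beyond the scatter at this position. They also leave open what an amine or a carboxylic acid in place of the chain would do on the shared core.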